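Inverting One Ring Stereocentre in a Shared Core

This account rests on a few compounds, and the source may have more. Where it says the series, first, only, none or still open, it means among the compounds named here.

compound 1 `CN1CCN(c2ccc(Nc3ncc4nc(Nc5ccc(F)cc5)n([C@H]5CCCN(C(=O)CO)C5)c4n3)cc2)CC1` gives 1.8 nM
compound 2 `CN1CCN(c2ccc(Nc3ncc4nc(Nc5ccccc5)n([C@H]5CCNC5)c4n3)cc2)CC1` gives 530 nM
compound 3 `CN1CCN(c2ccc(Nc3ncc4nc(Nc5ccccc5)n([C@@H]5CCN(S(=O)(=O)C6CC6)C5)c4n3)cc2)CC1` gives 0.88 nM

In a functional assay on HCC827 cells (Homo sapiens) for antiproliferative activity, read by MTT assay, with a stated time of 72 h (on this read-out lower numbers stand for stronger inhibition and higher numbers for weaker inhibition), compound 1 stands second highest of the three numbers; its nearest neighbour is compound 3 with 0.88 nM, its furthest compound 2 with 530 nM. Compound 4 `CN1CCN(c2ccc(Nc3ncc4nc(Nc5ccc(F)cc5)n([C@@H]5CCCN(C(=O)CO)C5)c4n3)cc2)CC1` is built from compound 1 by a single alteration: the two compounds have the same atoms and bonds and differ only in configuration as drawn: 1 of 1 stereo elements differ; a stereocentre at a saturated ring carbon is drawn S in compound 1 and R in compound 4. Among the measured compounds shown here, the only measured step, a 600-fold lower number from compound 2 to compound 3 (2.78 log units; beyond the scatter), concerns a substituent on a ring nitrogen and says nothing about configuration, so no step in hand bears on this change. Without an anchor, compound 4 is expected to stay close to compound 1, with the direction left open; this corresponds to an expected step of a 2.8-fold higher number from compound 1 to compound 4 (0.44 log units; beyond the scatter). Compound 4 is accordingly estimated at 5 nM, within a range from 1.2 nM to 40 nM.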

Compound 4, half-maximal inhibitory concentration: 66 nM
Compound 4: the middle estimate sits 13-fold (1.12 log units) below what was measured; measured number outside the range, above it.
By their numbers in this assay, from the lowest: compound 3; then compound 1; then compound 4; then compound 2.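

In this assay, among the compounds shown here, the stereocentre at a saturated ring carbon matters on its own, with a 37-fold higher number from compound 1 to compound 4 (1.56 log units; beyond the scatter) as S gives way to R. The earlier compounds showed only what a substituent on a ring nitrogen can do, whereas here the whole step can be put down to configuration: the fact that compounds 1 and 4 differ only in the configuration as drawn. On these data alone, whether the same configuration gives the lower number with the 1-(cyclopropylsulfonyl)pyrrolidin-3-yl of compound 3 stays open, as does whether it does so when the ring nitrogen of compound 1 carries a longer chain ending in an amine or a carboxylic acid.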